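Flipping One Ring Stereocentre of Compound 1

The source may hold more compounds than are shown below. What is called first, only, known or untested is meant among the compounds shown, and "the series" means these compounds.

Compound 1 `O=[N+]([O-])c1cn2c(n1)[S@+]([O-])C[C@H](OCc1ccc(OC(F)(F)F)cc1)C2` has been tested in an ADME assay on L929 cells (Mus musculus) for cytotoxicity (on this read-out higher numbers stand for weaker inhibition and lower numbers for stronger inhibition), and compound 1 gives > 10 ug/mL as its result, which is a limit of the assay and not a number. Compound 2 `O=[N+]([O-])c1cn2c(n1)S(=O)(=O)CC(OCc1ccc(OCc3ccccc3)cc1)C2` gives > 10 ug/mL in this assay and this too is a limit. That makes the limit of > 10 ug/mL in this assay, at which 2 of the 2 values shown sit, the whole of the evidence so far. Compound 3 `O=[N+]([O-])c1cn2c(n1)[S@+]([O-])C[C@@H](OCc1ccc(OC(F)(F)F)cc1)C2` is still unmeasured, and it relates to compound 1 through one change: the two compounds have the same atoms and bonds and differ only in configuration as drawn: 1 of 2 stereo elements differ; a stereocentre at a saturated ring carbon is drawn R in compound 1 and S in compound 3 (a stereocentre at a saturated ring carbon is drawn R in compound 1 and S in compound 3). Within the data shown here, no measured step shows what such a change does, so no shift beyond the usual scatter is expected in this assay for this pair. The expected step that the limit leaves unreadable from compound 1 to compound 3 is only an estimate resting on a limit. For compound 3 the estimated value is 15 ug/mL with a range from 8 ug/mL to 40 ug/mL and a limit is the likeliest report.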

Compound 3, half-maximal inhibitory concentration: > 10 ug/mL
Compound 3 gave a limit, no number; the forecaster's own chance of this, stated with the estimate: 85%; the middle value lies beyond the limit too.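

Among these compounds, compound 1 and compound 3 each give only a limit in this assay, not a number, so no step between them can be read: the limit of > 10 ug/mL in this assay, at which 3 of the 3 values shown sit. Whether flipping the ring stereocentre changes the result at all remains open, as does the true value of any compound shown.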